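Acetyl to fluoro on the pendant phenyl of compound 1

The source may hold more compounds than are shown below. What is called first, only, known or untested is meant among the compounds shown, and "the series" means these compounds.

Measured compounds:
compound 1, `COc1cc(-c2ccnc3cc(-c4ccc(C(C)=O)cc4)nn23)cc(OC)c1OC`, 4390 nM
compound 2, `Cc1ccc(-c2cc3nccc(-c4ccc(F)cc4)n3n2)cc1`, > 10000 nM

Among the compounds with values here, in a functional assay on HCT-116 cells (Homo sapiens) for inhibition, read by CCK-8 assay, with a stated time of 48 h (on this read-out higher numbers stand for weaker inhibition and lower numbers for stronger inhibition), compound 1 gives 4390 nM, the only number among the two values shown. For compound 2 this assay reports only a limit, > 10000 nM, (the limit of > 10000 nM in this assay, at which 1 of the 2 values shown sits). Compound 3, `COc1cc(-c2ccnc3cc(-c4ccc(F)cc4)nn23)cc(OC)c1OC`, has not yet been measured; it differs from compound 1 by fluoro in place of acetyl on an aromatic carbon. Within the data shown here, no measured pair shows this change alone. The step is expected to lose potency beyond the scatter, a 1.8-fold higher number from compound 1 to compound 3 (0.26 log units; within the scatter). Compound 3 is therefore estimated at 8000 nM, within 3000 nM to 25000 nM.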

Compound 3, half-maximal inhibitory concentration: 5030 nM
The estimate for compound 3 lay 1.6-fold (0.20 log units) above the measured number, and the stated range covers the measured number.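

In this assay, the aromatic carbon para to a large group on the pendant phenyl accepts fluoro in place of acetyl, with a 1.1-fold higher number from compound 1 to compound 3 (0.06 log units; within the scatter). The acetyl group, with its carbonyl, is therefore not required for the activity of compound 1 on this read-out. Nothing shown bears on why the two groups read alike.

As far as these compounds go, whether an amine or a carboxylic acid at this place would move the number beyond the scatter remains open. Also open, from the compounds shown here alone, is whether an unsubstituted phenyl would hold the same level.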